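A few compounds are considered here, and "the series" means these few. Any claim that something is new, unique, unknown or untested is made for them only; others in the source may bear on it.

Compound 1 `Cc1n[nH]c2nc(-c3ccc(NS(=O)(=O)c4cc(Cl)ccc4F)cc3)nc(OCC3CN(C(C)C)C3)c12`: 1 nM
Compound 2 `Cc1n[nH]c2nc(-c3ccc(NS(=O)(=O)c4cc(Cl)ccc4F)cc3)nc(OC3CC(C)(C)NC(C)(C)C3)c12`: 3 nM

In an assay for inhibition of serine/threonine-protein kinase Sgk1 (Homo sapiens), with stated times of 30 min and 60 min, in the presence of a further agent that is not named here (on this read-out lower numbers stand for stronger inhibition and higher numbers for weaker inhibition), compound 1 gives 1 nM and compound 2 gives 3 nM, so compound 2 carries the higher of the two numbers. For the measured compounds named here, the single measured step, a 3.0-fold higher number from compound 1 to compound 2 (0.48 log units; beyond the scatter), is modest and concerns the same place that changes next. Compound 3 `CCN1CCCC(Oc2nc(-c3ccc(NS(=O)(=O)c4cc(Cl)ccc4F)cc3)nc3[nH]nc(C)c23)C1` differs from compound 2 in one place: 1-ethylpiperidin-3-yl in place of 2,2,6,6-tetramethylpiperidin-4-yl on an oxygen on an aromatic ring. Going by the values given here, since the only comparable change shifted the number modestly, a small move at most is expected here. Compound 3 is therefore expected to give about 2 nM (range 0.6 nM to 6 nM), an expected step of a 1.5-fold lower number from compound 2 to compound 3 (0.18 log units; within the scatter) that need not exceed the usual scatter.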

Compound 3, half-maximal inhibitory concentration: 6 nM
For compound 3 the middle estimate is 3.0-fold (0.48 log units) below the measured one, and the stated range covers the measured number.
By their numbers in this assay, from the lowest: compound 1; then compounds 2 and 3 (each within the scatter of the next).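

In this assay the step of a 2.0-fold higher number from compound 2 to compound 3 (0.30 log units; within the scatter) stays within the scatter, so 1-ethylpiperidin-3-yl and 2,2,6,6-tetramethylpiperidin-4-yl on this oxygen cannot be told apart, although the latter counts a hydrogen-bond donor and the former none. Replacing the (1-isopropylazetidin-3-yl)methyl group of compound 1 gives a 6.0-fold higher number from compound 1 to compound 3 (0.78 log units; beyond the scatter) as the widest gap so far, still only modest. Nothing at hand accounts for these differences.

The compounds shown leave open how a carboxylic acid or a plain cyclohexyl ring, with no ring nitrogen, would fare on this oxygen.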